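Aryl swap at the enone terminus of compound 1

This account rests on a few compounds, and the source may have more. Where it says the series, first, only, none or still open, it means among the compounds named here.

The series shares a core in which an enone bridges an aryl ring and a phenoxy-linked dithiocarbamate. Compound 1 `O=C(/C=C/c1cccs1)c1ccc(OCCSC(=S)N2CCCC2)cc1` gives 18300 nM in a functional assay on ECa-109 cells for inhibition, with ECa-109 cell line (Homo sapiens) as the target, read by MTT assay, with a stated time of 72 h (on this read-out lower numbers stand for stronger inhibition and higher numbers for weaker inhibition), the highest of the two numeric values in the set; compound 3 `CN1CCN(C(=S)SCCCOc2ccc(C(=O)/C=C/c3cc(Cl)cc(Cl)c3)cc2)CC1` gives 12400 nM, a gap that stays within the scatter. Compound 2 `COc1ccc(/C=C/C(=O)c2ccc(OCCCSC(=S)N3CCN(C)CC3)cc2)cc1` returns only a limit, > 100000 nM, which is the assay limit noted as the limit of > 100000 nM in this assay, at which 1 of the 3 values shown sits. For the measured compounds named here, the one measured step, an at least 8.0-fold lower number from compound 2 to compound 3 (0.90 log units; beyond the scatter), shows that a chlorinated phenyl at this position brings a markedly lower number than a methoxyphenyl. Compound 4 `O=C(/C=C/c1ccc(Cl)cc1)c1ccc(OCCSC(=S)N2CCCC2)cc1` differs from compound 1 by 4-chlorophenyl in place of thiophen-2-yl on a double-bonded chain carbon bound to a double-bonded chain carbon. Going by the values given here, no measured pair covers a thiophen-2-yl to chlorophenyl exchange directly, so the step from compound 2 to compound 3 is the only guide, and it concerns the entry of chlorine on the aryl ring rather than the departure of the thiophene. For compound 4 a modest lowering is expected, a 1.8-fold lower number from compound 1 to compound 4 (0.26 log units; within the scatter), with a fair chance that it stays within the scatter. The estimate for compound 4 in this assay is 10000 nM, between 3000 nM and 40000 nM.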

Compound 4, half-maximal inhibitory concentration: 27800 nM
For compound 4 the middle estimate is 2.8-fold (0.44 log units) below the measured one; the measured number falls inside the stated range.
By their numbers in this assay, from the lowest: compounds 3, 1 and 4 (each within the scatter of the next, the first and the last beyond it). At a limit, above all of these: compound 2.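

Within the shared core of compound 1, the exchange of thiophen-2-yl for 4-chlorophenyl in this assay gives a 1.5-fold higher number from compound 1 to compound 4 (0.18 log units; within the scatter), so the two rings cannot be told apart at this position, and the entry of a single chlorine-bearing phenyl brings no measurable gain here. The large step seen so far, an at least 8.0-fold lower number from compound 2 to compound 3 (0.90 log units; beyond the scatter), therefore does not extend to every chlorinated phenyl exchange on a double-bonded chain carbon bound to a double-bonded chain carbon: it started from 4-methoxyphenyl and ended at 3,5-dichlorophenyl, and compound 1 and compound 4 go against any general rule that chlorine on this ring lowers the number. No measurement shown here accounts for the outcome of this exchange.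

The compounds shown leave open how 4-methoxyphenyl or 3,5-dichlorophenyl would read at this position with the rest of compound 1 held fixed, and whether 4-chlorophenyl would behave the same way with the rest of compound 3. Also open, from the compounds shown here alone, is how this position responds to a ring carrying an amine or a carboxylic acid, or to a longer chain in place of the ring.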